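This account rests on a few compounds, and the source may have more. Where it says the series, first, only, none or still open, it means among the compounds named here.

Measured in a functional assay on PC-3 cells (Homo sapiens) for cytotoxicity, with a stated time of 48 h; on this read-out higher numbers stand for weaker inhibition and lower numbers for stronger inhibition:
- compound 1 `COc1cccc(/C=C/C(=O)c2c(OC)cc(OC)cc2OC)c1`: 3100 nM
- compound 2 `COc1cc(OC)c(C(=O)/C=C/c2ccc(Cl)cc2)c(OC)c1`: 5800 nM

Going by the values given here, compound 2 cannot be told apart from compound 1, the only other measured compound. Compound 3 `COc1cc(OC)c(C(=O)/C=C/c2ccc([N+](=O)[O-])cc2)c(OC)c1` is next, with nitro in place of chloro on an aromatic carbon, para to a large group. Among the compounds with values here, the only measured step bearing on this change, 4-chlorophenyl in place of 3-methoxyphenyl, is a 1.9-fold higher number from compound 1 to compound 2 (0.27 log units; within the scatter). Within the data shown here, no nitro compound has been measured, so with only that step to go on, no step beyond the scatter is expected in this assay, in either direction. The expected change is a 1.5-fold lower number from compound 2 to compound 3 (0.16 log units; within the scatter). For compound 3 the estimate is 4000 nM, with an expected range of 1200 nM to 12000 nM.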

Compound 3, half-maximal inhibitory concentration: 2500 nM
Compound 3: the middle estimate sits 1.6-fold (0.20 log units) above what was measured, and the stated range covers the measured number.
By their numbers in this assay, from the lowest: compounds 3, 1 and 2 (each within the scatter of the next, the first and the last beyond it).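

Going by these compounds alone, at this aromatic carbon, para to a large group, nitro in place of chloro gives a 2.3-fold lower number from compound 2 to compound 3 (0.37 log units; beyond the scatter) in this assay and is the first step beyond the scatter, though a modest one. The number therefore responds to the group at this place, whereas the earlier change of the whole aryl group stayed within the scatter. No measured property offers an explanation for this step.

On these data alone, whether an amine or a carboxylic acid at this carbon would move the number further remains open. Also open, as far as these compounds go, is whether the same exchange would give a similar step at other places on the ring.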